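This account rests on a few compounds, and the source may have more. Where it says the series, first, only, none or still open, it means among the compounds named here.

Compound 1 `CCOc1ccc(-n2nncc2CN2C(=O)C3(C(C#N)=C(N)Oc4c(N)cc5nc6ccccc6nc5c43)c3ccccc32)cc1` sets the reference point: in a functional assay on MCF7 cells (Homo sapiens) for antiproliferative activity, read by MTT assay, with a stated time of 48 h (a higher number here means a weaker inhibitor, a lower number a stronger inhibitor), compound 1 gives 26800 nM. Compound 2 `CCOc1ccccc1-n1nncc1CN1C(=O)C2(C(C#N)=C(N)Oc3c(N)cc4nc5ccccc5nc4c32)c2ccccc21` gives only a limit of this assay, > 50000 nM, as told by the limit of > 50000 nM in this assay, at which 1 of the 2 values shown sits. Between them lies an at least 1.8-fold higher number from compound 1 to compound 2 (0.27 log units; that floor lies within the scatter). Compound 3 `N#CC1=C(N)Oc2c(N)cc3nc4ccccc4nc3c2C12C(=O)N(Cc1cnnn1-c1ccc([N+](=O)[O-])cc1)c1ccccc12` differs from compound 2 by 4-nitrophenyl in place of 2-ethoxyphenyl on an aromatic nitrogen. Among the measured compounds shown here, only that one measured step bears on this change, and it is small, so no shift beyond the scatter is expected. Compound 3 is therefore expected near 40000 nM, within a range from 15000 nM to 100000 nM. The expected step is an at least 1.2-fold lower number from compound 2 to compound 3 (0.09 log units; that floor lies within the scatter).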

Compound 3, half-maximal inhibitory concentration: > 50000 nM
Compound 3: a limit, no number; the forecaster's own chance of this, stated with the estimate: 45%; at least 1.2-fold (0.09 log units) between middle value and limit.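

Nitro in place of ethoxy on an aromatic carbon gives an at least 1.8-fold higher number from compound 1 to compound 3 (0.27 log units; that floor lies within the scatter), so compound 1 still holds the only true number in the series. Compound 2 and compound 3 both stop at a limit of this assay, so the step between them cannot be read. This position has now given two different aryl groups that reach the same ceiling: the limit of > 50000 nM in this assay, at which 2 of the 3 values shown sit.

From the compounds shown here alone, how far compound 2 and compound 3 lie past that limit stays open. So does whether an amine or a carboxylic acid in place of the nitro would give a readable number.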